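This account rests on a few compounds, and the source may have more. Where it says the series, first, only, none or still open, it means among the compounds named here.

Measured in a functional assay on L1210 cells (Mus musculus) for antiproliferative activity; a higher number here means a weaker inhibitor, a lower number a stronger inhibitor:
Compound 1 `COc1cc(C(=O)c2sc(-c3ccccc3)cc2N)cc(OC)c1OC`: 11 nM
Compound 2 `COc1cc(C(=O)c2sc(-c3ccc(Cl)c(Cl)c3)cc2N)cc(OC)c1OC`: 260 nM
Compound 3 `COc1cccc(-c2cc(N)c(C(=O)c3cc(OC)c(OC)c(OC)c3)s2)c1`: 22 nM

Two steps fix where compound 3 stands among these numbers: a 2.0-fold higher number from compound 1 to compound 3 (0.30 log units; within the scatter), which lies within the scatter, and a 12-fold lower number from compound 2 to compound 3 (1.07 log units; beyond the scatter), which goes well beyond it. The next compound is compound 4 `COc1cc(C(=O)c2sc(-c3cccs3)cc2N)cc(OC)c1OC`, with thiophen-2-yl in place of 3-methoxyphenyl on an aromatic carbon. Among the measured compounds shown here, no measured compound carries thiophen-2-yl, so the evidence is indirect. All three measured steps concern this same place. Compound 3 shows that a methoxy on the phenyl leaves the number within the scatter, at a 2.0-fold higher number from compound 1 to compound 3 (0.30 log units; within the scatter). Compound 2 shows that this place can also respond strongly, with the large step of a 24-fold higher number from compound 1 to compound 2 (1.37 log units; beyond the scatter). Of the two outcomes, the change to compound 4 is taken to resemble the first, though a rise in the number cannot be excluded. In this assay, no step beyond the scatter is therefore expected, and the estimated step is a 1.1-fold higher number from compound 3 to compound 4 (0.06 log units; within the scatter). For compound 4 the expected value is 25 nM, with an estimated range from 8 nM to 90 nM.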

Compound 4, half-maximal inhibitory concentration: 9.8 nM
For compound 4 the middle estimate is 2.6-fold (0.41 log units) above the measured one, and the stated range covers the measured number.
By their numbers in this assay, from the lowest: compounds 4, 1 and 3 (each within the scatter of the next, the first and the last beyond it); then compound 2.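

In this assay, this position accepts a five-membered aromatic ring with a sulfur in place of the unsubstituted six-membered ring without any change beyond the scatter, at a 1.1-fold lower number from compound 1 to compound 4 (0.05 log units; within the scatter). The same thiophen-2-yl gives a 2.2-fold lower number from compound 3 to compound 4 (0.35 log units; beyond the scatter), a modest step, and a 27-fold lower number from compound 2 to compound 4 (1.42 log units; beyond the scatter), a large one, so a step beyond the scatter now separates the 3-methoxyphenyl group from another group at this place, which the comparison with phenyl alone did not show. Nothing available explains why these groups differ.

The compounds shown leave open whether a thiophen-3-yl or a pyridinyl ring would behave like thiophen-2-yl. They also leave open how a thiophen-2-yl ring carrying a methyl, a chlorine or an amine would fare.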